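This account rests on a few compounds, and the source may have more. Where it says the series, first, only, none or still open, it means among the compounds named here.

Compound 1 `CCCCNc1nc(N)nc(C)c1CCCN(C)C` stands lowest of the two numbers obtained in an assay on HEK293 cells for agonist activity at Toll-like receptor 8 (Homo sapiens), read by spectrophotometry; on this read-out lower numbers stand for an effect already at smaller amounts and higher numbers for an effect only at larger amounts of compound. In this assay compound 1 gives 126 nM, while its nearest neighbour, compound 2 `CCCC#Cc1c(C)nc(N)nc1NCCCC`, gives 5000 nM. Among the compounds with values here, the one measured step, a 40-fold higher number from compound 1 to compound 2 (1.60 log units; beyond the scatter), puts pent-1-yn-1-yl in place of 3-(dimethylamino)propyl on an aromatic carbon, so it removes the amine altogether. Compound 3 `CCCCNc1nc(N)nc(C)c1CCCN(CC)CC` has not yet been measured. It differs from compound 1 as follows: diethylamino in place of dimethylamino on a saturated chain carbon, three bonds along the chain from an aromatic carbon. The chain and its nitrogen stay in place; only the substituents on that nitrogen grow. Within the data shown here, no measured step addresses such an exchange, and the step from compound 1 to compound 2 is too drastic to serve as a guide for it, so the expectation is a step of roughly a 1.3-fold higher number from compound 1 to compound 3 (0.10 log units; within the scatter), that is, nothing beyond the scatter. Compound 3 is therefore estimated at 160 nM, within a range from 50 nM to 500 nM.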

Compound 3, half-maximal effective concentration: 254 nM
Beside the measured number, compound 3's estimate is 1.6-fold (0.20 log units) below it; the range from low to high includes it.
By their numbers in this assay, from the lowest: compounds 1 and 3 (each within the scatter of the next); then compound 2.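

In this assay, diethylamino in place of dimethylamino on a saturated chain carbon, three bonds along the chain from an aromatic carbon, gives a 2.0-fold higher number from compound 1 to compound 3 (0.30 log units; within the scatter). The substituents on this nitrogen can therefore grow from methyl to ethyl without a change beyond the scatter. This contrasts with the earlier exchange of the whole chain and its amine, which gave a 40-fold higher number from compound 1 to compound 2 (1.60 log units; beyond the scatter) and so left open whether the groups on the nitrogen mattered at all. Nothing available offers an explanation for this result.

The compounds shown leave open whether dipropylamino or a ring amine such as pyrrolidine or morpholine would also stay within the scatter of compound 1. They also leave open what a longer chain to the nitrogen, or a carboxylic acid in place of the amine, would do.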